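The source may hold more compounds than are shown below. What is called first, only, known or untested is meant among the compounds shown, and "the series" means these compounds.

Measured compounds:
- Compound 1 `Cc1cccc([C@@H](O)C(=O)N2N=CC[C@H]2C(=O)NCc2cc(Cl)ccc2-n2cnnn2)c1`: 830 nM
- Compound 2 `O=C(NCc1cc(Cl)ccc1-n1cnnn1)[C@@H]1C[C@H]2C[C@H]2N1C(=O)[C@H](O)c1ccccc1`: 680 nM

Both compounds were tested in a functional assay on a cell-free system (plasma, Homo sapiens), with a stated time of 3 min; a lower number here means a stronger inhibitor, a higher number a weaker inhibitor. Compound 1 stands level with compound 2, since their two numbers lie within the scatter of each other and cannot be ranked.

Compound 3 `CC(C)CC[C@@H](O)C(=O)N1N=CC[C@H]1C(=O)NCc1cc(Cl)ccc1-n1cnnn1` has not yet been measured. It keeps the core of compound 1 but carries isopentyl in place of 3-methylphenyl on a saturated chain carbon bound to a carbonyl carbon and an oxygen on a saturated carbon. Among the compounds with values here, no measured pair shows this change, so the expectation is tentative and starts from compound 1 at 830 nM. A modest loss of strength is expected, just beyond the scatter, as the aromatic ring leaves and no ring enters. The estimated step is a 2.4-fold higher number from compound 1 to compound 3 (0.38 log units; beyond the scatter). For compound 3 the expected value is 2000 nM, with an estimated range of 600 nM to 7000 nM.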

Compound 3, half-maximal inhibitory concentration: 630 nM
Beside the measured number, compound 3's estimate is 3.2-fold (0.50 log units) above it; the range from low to high includes it.
By their numbers in this assay, from the lowest: compounds 3, 2 and 1 (each within the scatter of the next).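

In this assay, isopentyl in place of 3-methylphenyl on a saturated chain carbon bound to a carbonyl carbon and an oxygen on a saturated carbon gives a 1.3-fold lower number from compound 1 to compound 3 (0.12 log units; within the scatter), so the two compounds cannot be ranked. Among these compounds, then, an aromatic ring at this place is not needed for a number in this range, since isopentyl, with no ring, stands level with 3-methylphenyl. Nothing available explains this outcome.

The compounds shown leave open whether an amine, a carboxylic acid or a chain longer than isopentyl at this place would stay level with compound 1 or move the number beyond the scatter. They also leave open whether isopentyl would read the same way on the core of compound 2.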